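The source may hold more compounds than are shown below. What is called first, only, known or untested is meant among the compounds shown, and "the series" means these compounds.

In a functional assay on ECa-109 cells for inhibition, with ECa-109 cell line (Homo sapiens) as the target, read by sulforhodamine B assay (a lower number here means a stronger inhibitor, a higher number a weaker inhibitor), three compounds that share a core and differ in the group on an amine nitrogen have been measured. On these data alone, compound 3 `COc1ccc(NC2=CC(=O)c3nc4n(c3C2=O)[C@H]2OC[C@@H](O)[C@H]2OC4)cc1`, which carries 4-methoxyphenyl, reads > 4000 nM, and this is a limit, so its exact place is unknown. Compound 1 `O=C1C=C(NCc2ccccc2)C(=O)c2c1nc1n2[C@H]2OC[C@@H](O)[C@H]2OC1`, which carries benzyl, reads > 8000 nM, also a limit. Among the compounds with values here, compound 2 `O=C1C=C(Nc2ccccc2F)C(=O)c2c1nc1n2[C@H]2OC[C@@H](O)[C@H]2OC1`, with 2-fluorophenyl, gives the only actual number, 2760 nM.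

Compound 4 `COc1cccc(NC2=CC(=O)c3nc4n(c3C2=O)[C@H]2OC[C@@H](O)[C@H]2OC4)c1` keeps the same atoms but joins them differently: 3-methoxyphenyl in place of 4-methoxyphenyl on an amine nitrogen.

Within the data shown here, no measured step makes this exact move, so the nearest ones serve only as loose guides. Replacing benzyl gave an at least 2.8-fold lower number from compound 1 to compound 2 (0.46 log units; beyond the scatter). Exchanging one substituted phenyl group for another gave an at least 1.4-fold higher number from compound 2 to compound 3 (0.16 log units; that floor lies within the scatter), and replacing benzyl with 4-methoxyphenyl gave a step that the two limits leave unreadable from compound 1 to compound 3. A change within the substituted phenyl groups is therefore expected to be small, with no clear direction beyond the scatter. The estimate amounts to an expected at least 1.1-fold lower number from compound 3 to compound 4 (0.05 log units; that floor lies within the scatter). For compound 4 the expected value is 3500 nM, within an estimated range of 1500 nM to 8000 nM.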

Compound 4, half-maximal inhibitory concentration: 7620 nM
The estimate for compound 4 lay 2.2-fold (0.34 log units) below the measured number, and the stated range covers the measured number.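

In this assay, within the data shown here, compound 4 gives the first actual number for a methoxyphenyl group on this amine nitrogen, and it sets that group apart from 2-fluorophenyl, with a 2.8-fold higher number from compound 2 to compound 4 (0.44 log units; beyond the scatter). Against benzyl nothing is settled, with an at least 1.0-fold lower number from compound 1 to compound 4 (0.02 log units; that floor lies within the scatter), and that step rests on a limit for compound 1. The step between compound 3 and compound 4 cannot be read, so the effect of shifting the methoxy group from 4-methoxyphenyl to 3-methoxyphenyl stays unknown because compound 3 is held at a limit: the limit of > 4000 nM in this assay, at which 1 of the 4 values shown sits.

The compounds shown leave open how plain phenyl or 3-fluorophenyl would read on this nitrogen, which would show whether the fluorine or the methoxy group matters more. They also leave open what a phenyl ring bearing an amine or a carboxylic acid, or a longer chain in place of benzyl, would do.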